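The source may hold more compounds than are shown below. What is called first, only, known or untested is meant among the compounds shown, and "the series" means these compounds.

Measured so far:
- compound 1 `COc1cccc(N2CCN(C(=O)C(C)N3C(=O)CCC3=O)CC2)c1` — 0%
- compound 2 `COCC(C(=O)N1CCN(c2cccc(C(F)(F)F)c2)CC1)N1C(=O)CCC1=O` — 0%
- compound 3 `CCC(C(=O)N1CCN(c2ccccc2)CC1)N1C(=O)CCC1=O` — 0%

Within the data shown here, the three compounds measured so far share a core and differ in the group carried on the ring nitrogen and in the substituent beside the succinimide. In a functional assay on the whole organism (strain Swiss) with Mus musculus as the target, in the maximal electroshock model, with a stated time of 2 h, at a dose of 100 mg/kg by the intraperitoneal route (on this read-out higher numbers stand for a stronger effect at the one dose given and lower numbers for a weaker effect), compound 1 gives 0%. In the same test compound 2 gives 0%, and compound 3 gives 0%. Compound 1 therefore stands level with compounds 2 and 3 at the digits reported; its nearest neighbour on this read-out is compound 2 and its furthest is compound 3, yet neither gap goes beyond the usual scatter of repeated measurements. Among the measured compounds shown here, no step between two measured compounds is known to move the number at all.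

Compound 4 `CC(C(=O)N1CCN(c2ccc(Cl)cc2)CC1)N1C(=O)CCC1=O` has not yet been measured. It differs from compound 1 as follows: 4-chlorophenyl in place of 3-methoxyphenyl on an amine nitrogen in a ring. Three compounds with varied groups on that ring nitrogen all sit at the same reading, so no direction for this change can be drawn from them. The step is expected to be a number 5 percentage points higher from compound 1 to compound 4 (within the scatter), that is, none beyond the scatter. For compound 4 the estimated activity is 5%, with a range from 0% to 25%.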

Compound 4, a percentage reported as activity, at one dose (the size of the read-out at that dose, not a potency): 0%
Beside the measured number, compound 4's estimate is 5 percentage points above it, within the range that was stated.
By their numbers in this assay, from the lowest: compounds 1, 2, 3 and 4 (each within the scatter of the next).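

Among these compounds, the swap of 3-methoxyphenyl for 4-chlorophenyl on the amine nitrogen in a ring gives the only step here between two compounds that differ in one place, and in this assay it reads no change at the digits printed from compound 1 to compound 4 (within the scatter) (within the scatter). The earlier compounds shown here differed in more than one place and so could not speak for this position alone, whereas this pair shows that moving from a ring substituent with one hydrogen-bond acceptor to one with none leaves the reading unchanged at this single dose and time. No measured information bears on why the reading stays the same.

Because both members of the pair give the same reading, they leave open whether any group at this position can raise the number in this assay at all, for instance a benzyl group, or a phenyl ring carrying an amine or a carboxylic acid. Also open, going by these compounds, is whether the same change would read differently on a compound that already shows some activity in this assay, since a step measured from a reading of nothing says little about such a case.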